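Triazenes on L1210: benzyl to ethynyl exchange

The source may report more compounds than this note shows. Statements on the series, on what has been measured and on what is new or still open speak of the compounds shown alone.

Measured compounds:
compound 1, `CN(C)/N=N/c1ccc(S(N)(=O)=O)cc1C(N)=O`, 3.32
compound 2, `CN(Cc1ccccc1)/N=N/c1nc[nH]c1C(N)=O`, 3.43
compound 3, `CN(C)/N=N/c1ccc(C#N)cc1C(N)=O`, 3.46

All three were run in a functional assay on L1210 cells (Mus musculus) for antiproliferative activity; on this read-out higher numbers stand for higher potency (the scale is a negative logarithm) and lower numbers for lower potency. Compound 2 stands second highest of the three numbers; its nearest neighbour is compound 3, and its furthest is compound 1, and both gaps lie within the scatter, so the three values are not told apart on this read-out.

For the measured compounds named here, the one measured step that changes a single place, a number 0.14 log units higher from compound 1 to compound 3 (within the scatter), lies within the scatter. It alters a substituent on the aromatic carbon of the core of compound 1 and says nothing about the chain carbon bound to the amine nitrogen.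

Compound 4, `C#CCN(C)/N=N/c1nc[nH]c1C(N)=O`, has not been measured. It differs from compound 2 as follows: ethynyl in place of phenyl on a saturated chain carbon bound to an amine nitrogen. Going by the values given here, no measured pair shows a change at this place, so no step on record bears on it. In the absence of such a step, and given that the three measured values sit together, the step is expected to fall within the scatter: a number 0.03 log units lower from compound 2 to compound 4 (within the scatter). Compound 4 is therefore estimated at 3.4, with a range from 3 to 3.8.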

Compound 4, logarithm of the reciprocal of the active concentration, log(1/C): 3.61
The estimate for compound 4 lay 0.21 log units below the measured number, within the range that was stated.
By their numbers in this assay, from the lowest: compounds 1, 2, 3 and 4 (each within the scatter of the next).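

In this assay, for the compounds shown here, the first step on record at this place, ethynyl in place of phenyl on a saturated chain carbon bound to an amine nitrogen, is a number 0.18 log units higher from compound 2 to compound 4 (within the scatter) and so does not separate the two compounds. The step is a large change in structure, with 6 heavy atoms and a six-membered aromatic ring of carbon only leaving and 2 heavy atoms with a triple bond entering, so on this read-out the aromatic ring at this place is not required to keep the number within the scatter of the value with phenyl. Nothing at hand accounts for the size of this step, and no separate measurement bears on what either group does here.

Still open, as far as these compounds go, is whether another group at this place, such as a carboxylic acid, an amine or a longer chain, would give a step beyond the scatter. The exchange is also seen on one core only, so whether it would read the same on the core of compound 3 remains an open question.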